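This account rests on a few compounds, and the source may have more. Where it says the series, first, only, none or still open, it means among the compounds named here.

Measured so far in an ADME assay on HepG2 2.2.15 cells (Homo sapiens) for cytotoxicity, read by MTT assay; a lower number here means that less compound is tolerated, a higher number that more compound is tolerated:

Compound 1 `CC(=O)c1ccc(OC(=O)c2ccccc2)cc1` gives > 3340000 nM.
Compound 2 `CC(=O)c1ccc(OC(=O)c2cccnc2)cc1` gives 3010000 nM.
Compound 3 `CC(=O)c1ccc(O[C@@H]2O[C@H](COC(=O)c3ccccc3)[C@@H](O)[C@H](O)[C@H]2O)cc1` gives 1050000 nM.

The value of compound 1 is a limit of the assay rather than a number: it sits at the limit of > 3340000 nM in this assay, at which 1 of the 3 values shown sits. Compound 1 and compound 2 differ in one place, (pyridin-3-yl in place of phenyl on a carbonyl carbon), and this change produced an at least 1.1-fold lower number from compound 1 to compound 2 (0.04 log units; that floor lies within the scatter). Compound 3 is built on a different core; how the core of compound 3 differs from the core of compound 1 is not broken down here. Compound 4 `CC(=O)c1ccc(O[C@@H]2O[C@H](COC(=O)c3cccnc3)[C@@H](O)[C@H](O)[C@H]2O)cc1` has not yet been measured. It is made from compound 3 by the same change, (pyridin-3-yl in place of phenyl on a carbonyl carbon), at a place described in the same words as for the pair of compound 1 and compound 2.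

Because the measured step of an at least 1.1-fold lower number from compound 1 to compound 2 (0.04 log units; that floor lies within the scatter) lies within the scatter and rests on a limit, only a small step is expected from compound 3 to compound 4, namely a 1.2-fold lower number from compound 3 to compound 4 (0.07 log units; within the scatter). Compound 4 is accordingly estimated at 900000 nM, most likely between 450000 nM and 1800000 nM in this assay.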

Compound 4, half-maximal cytotoxic concentration: > 1650000 nM
Compound 4: a limit, no number; the forecaster's own chance of this, stated with the estimate: 5%; middle value at least 1.8-fold (0.26 log units) from the limit.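

In this assay, compound 4 gives > 1650000 nM, which is a limit of the assay and not a number. On this second core, pyridin-3-yl in place of phenyl on a carbonyl carbon gives an at least 1.5-fold higher number from compound 3 to compound 4 (0.19 log units; that floor lies within the scatter), so the data fix only a floor for the step and not its size. Set beside the first core, this shows neither that the change carries over unaltered nor that its outcome depends on the core: the same change on two cores in this assay, an at least 1.1-fold lower number (0.04 log units; that floor lies within the scatter) from compound 1 to compound 2 and an at least 1.5-fold higher number (0.19 log units; that floor lies within the scatter) from compound 3 to compound 4; the limit leaves it open whether they differ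

The compounds shown leave open how large the step truly is on either core, since compound 1 and compound 4 both end in limits rather than numbers. They also leave open what happens in this cytotoxicity read-out when the same carbonyl carbon carries something other than these two rings, such as pyridin-4-yl or a phenyl ring bearing an amine or a carboxylic acid.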